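A few compounds are considered here, and "the series" means these few. Any claim that something is new, unique, unknown or untested is made for them only; others in the source may bear on it.

Compound 1 `O=C(O)CCNC(=O)c1ccc(CN(c2ccc(Cl)cc2)c2nc(-c3ccc(C(F)(F)F)cc3)cs2)cc1`: 410 nM
Compound 2 `O=C(O)CCNC(=O)c1ccc(CN(c2ccc(C(F)(F)F)cc2)c2nc(-c3ccc(Cl)cc3)cs2)cc1`: 1100 nM

Both numbers come from an in vitro assay on BHK cells for binding affinity to gastric inhibitory polypeptide receptor (Homo sapiens); on this read-out lower numbers stand for stronger inhibition and higher numbers for weaker inhibition. Compound 1 gives the lowest of the two; compound 2 gives a higher number, and the gap between them lies beyond the scatter. Compound 3 `O=C(O)CCNC(=O)c1ccc(CN(c2ccc3c(c2)CCC3)c2nc(-c3ccc(C(F)(F)F)cc3)cs2)cc1` is not yet measured. It differs from compound 1 in one place: 2,3-dihydro-1H-inden-5-yl in place of 4-chlorophenyl on a nitrogen on an aromatic ring. Among the compounds with values here, no measured pair shows this change, so its effect is unknown, and a step of modest size in either direction, or none beyond the scatter, is all that can be said. For compound 3 the expected value in this assay is 600 nM, in a range from 150 nM to 2500 nM. The expected step is a 1.5-fold higher number from compound 1 to compound 3 (0.17 log units; within the scatter).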

Compound 3, half-maximal inhibitory concentration: 510 nM
Compound 3: middle estimate off by 1.2-fold (0.07 log units), on the high side; the measured number falls inside the stated range.
By their numbers in this assay, from the lowest: compounds 1 and 3 (each within the scatter of the next); then compound 2.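

In this assay, placing 2,3-dihydro-1H-inden-5-yl instead of 4-chlorophenyl on this nitrogen gives a 1.2-fold higher number from compound 1 to compound 3 (0.09 log units; within the scatter) and so leaves the reading unchanged within the scatter. This position therefore tolerates losing the chlorine and adding a five-membered non-aromatic ring, at least in this one pair. Nothing measured here explains this result.

Going by these compounds, whether a plain phenyl, or a phenyl carrying an amine or a carboxylic acid, would read the same remains open. So does whether this tolerance holds with 4-chlorophenyl on the thiazole's other aryl position replaced.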